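From ethoxy to methylsulfanyl: what compound 4 may show

This account rests on a few compounds, and the source may have more. Where it says the series, first, only, none or still open, it means among the compounds named here.

In a functional assay on MCF7 cells (Homo sapiens) for cytotoxicity (on this read-out lower numbers stand for an effect already at smaller amounts and higher numbers for an effect only at larger amounts of compound), compound 3 `CCOc1ccc(/C=C\c2cc(OC)c(OC)c(OC)c2)cc1` gives 9.6 uM. That lies within the usual scatter of compound 2 `COc1cc(/C=C/c2ccc(SC)cc2)cc(OC)c1OC`, which gives 5.9 uM, while compound 1 `COc1cc(/C=C\c2ccc(C(C)(C)C)cc2)cc(OC)c1OC` gives a clearly lower 1.57 uM. Compound 4 `COc1cc(/C=C\c2ccc(SC)cc2)cc(OC)c1OC` carries methylsulfanyl in place of ethoxy on an aromatic carbon. Among the measured compounds shown here, the one measured swap of this kind, a 6.1-fold higher number from compound 1 to compound 3 (0.79 log units; beyond the scatter), shows that such a change can register in this assay. Yet compound 2, which also carries methylsulfanyl but has the opposite geometry at its double bond, gives 5.9 uM, close to compound 3. The expected step, a 1.7-fold lower number from compound 3 to compound 4 (0.24 log units; within the scatter), is therefore small. For compound 4 the estimated value is 5.5 uM, with an expected range of 1.7 uM to 17 uM.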

Compound 4, concentration for half-maximal effect: 5.4 uM
Beside the measured number, compound 4's estimate is 1.0-fold (0.01 log units) above it; measured number inside the range.
By their numbers in this assay, from the lowest: compound 1; then compounds 4, 2 and 3 (each within the scatter of the next).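

In this assay, methylsulfanyl in place of ethoxy reads as a 1.8-fold lower number from compound 3 to compound 4 (0.25 log units; within the scatter), while methylsulfanyl in place of tert-butyl reads as a 3.4-fold higher number from compound 1 to compound 4 (0.54 log units; beyond the scatter), so among compounds 1, 3 and 4 only tert-butyl stands apart. The geometry of the double bond can now be read directly, and with methylsulfanyl it gives a 1.1-fold lower number from compound 2 to compound 4 (0.04 log units; within the scatter). This comparison isolates a single feature: the fact that compounds 2 and 4 differ only in the configuration as drawn.

On these data alone, whether an amine, a carboxylic acid or a longer chain here would fall with compounds 3 and 4 or with compound 1 stays open. So does whether double-bond geometry matters as little with tert-butyl or ethoxy in place.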